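This account rests on a few compounds, and the source may have more. Where it says the series, first, only, none or still open, it means among the compounds named here.

Measured compounds:
- compound 1, `CCOC(=O)C1=C(N/C=N/c2cccnc2Cl)Nc2[nH]nc(C)c2C1c1ccc(N(C)C)cc1`, gives 4630 nM
- compound 2, `CCOC(=O)C1=C(N/N=C(\C#N)C(N)=O)Nc2[nH]nc(C)c2C1c1ccc(N(C)C)cc1`, gives 47300 nM
- compound 3, `CCOC(=O)C1=C(NN=C(C(C)=O)C(C)=O)Nc2[nH]nc(C)c2C1c1ccc(N(C)C)cc1`, gives 17000 nM

These three share one core and differ only in the group attached to an amine nitrogen. In a functional assay on HeLa cells (Homo sapiens) for inhibition, read by MTT assay, with a stated time of 48 h (a higher number here means a weaker inhibitor, a lower number a stronger inhibitor), compound 3 stands second highest of the three numbers. Its nearest neighbour is compound 2, and the step of a 2.8-fold lower number from compound 2 to compound 3 (0.44 log units; beyond the scatter) is beyond the scatter; its furthest is compound 1, and the step of a 3.7-fold higher number from compound 1 to compound 3 (0.56 log units; beyond the scatter) is also beyond the scatter, so compound 3 sits between the two.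

Compound 4, `CCOC(=O)C1=C(N/N=C(/C(C)=O)C(=O)OCC)Nc2[nH]nc(C)c2C1c1ccc(N(C)C)cc1`, has not yet been measured. It differs from compound 3 in one place: a group of 10 heavy atoms (6 carbon, 1 nitrogen, 3 oxygen; no ring) in place of a group of 8 heavy atoms (5 carbon, 1 nitrogen, 2 oxygen; no ring), on an amine nitrogen. The group that leaves and the group that enters are both open chains without rings, and both attach at the same amine nitrogen where every change in this small series has been made.

Going by the values given here, the steps that bear on this are those at the same position. The change from compound 1 to compound 3 gave a 3.7-fold higher number from compound 1 to compound 3 (0.56 log units; beyond the scatter), and the change from compound 2 to compound 3 gave a 2.8-fold lower number from compound 2 to compound 3 (0.44 log units; beyond the scatter); both are modest, while only the ring-to-chain change from compound 1 to compound 2 was large, a 10-fold higher number from compound 1 to compound 2 (1.01 log units; beyond the scatter). Chain-to-chain swaps here have so far moved the number modestly. The step from compound 3 to compound 4 is therefore expected to be a 1.1-fold lower number from compound 3 to compound 4 (0.05 log units; within the scatter), of uncertain direction and possibly within the scatter. Compound 4 is expected to give about 15000 nM, between 6000 nM and 40000 nM.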

Compound 4, half-maximal inhibitory concentration: > 100000 nM
Compound 4 ended at the assay's limit (the forecaster's own chance of this, stated with the estimate: 10%); middle value at least 6.6-fold (0.82 log units) from the limit.
By their numbers in this assay, from the lowest: compound 1; then compound 3; then compound 2. At a limit, above all of these: compound 4.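

In this assay compound 4 stands at a limit and not at a measured number: the limit of > 100000 nM in this assay, at which 1 of the 4 values shown sits. Even so, a swap of one open chain for another at this amine nitrogen, with 10 heavy atoms in place of 8 and 4 hydrogen-bond acceptors in place of 3, is not always a modest change, as it gives an at least 5.8-fold higher number from compound 3 to compound 4 (0.76 log units; beyond the scatter). The ester-bearing chain of compound 4 also reads higher than the other open chain, with an at least 2.1-fold higher number from compound 2 to compound 4 (0.32 log units; beyond the scatter), and than the only group here with a ring, with an at least 21-fold higher number from compound 1 to compound 4 (1.33 log units; beyond the scatter), so all three open chains shown are weaker than that ring-bearing group, and no compound goes against this.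

As far as these compounds go, these steps are only lower bounds, so the true distance of compound 4 from the others stays unknown, and a single comparison cannot tell which part of the new chain matters. The compounds shown also leave open how a carboxylic acid, an amine, or a simple phenyl ring without chlorine would behave on this same nitrogen, and whether any such group would read lower than compound 1.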